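Amide chain lengthening in the shared-core series

The source may report more compounds than this note shows. Statements on the series, on what has been measured and on what is new or still open speak of the compounds shown alone.

Going by the values given here, compound 3 `CCCNC(=O)CC1CCc2cc(OC)c(OC)cc21` stands second highest of the three numbers so far: in a functional assay on the whole organism (strain Wistar) for inhibition, with Rattus norvegicus as the target, read by paw edema, with stated times of 60 min and 1 h, at a dose of 100 mg/kg by the oral route (a higher number here means more inhibition at the dose given (going by the name of the read-out), a lower number less inhibition), compound 3 gives 18.8%, while compound 1 `CCNC(=O)CC1CCc2cc(OC)c(OC)cc21` gives 15.6% and compound 2 `CCN(CC)C(=O)CC1CCc2cc(OC)c(OC)cc21` gives 31.3%. The step of a number 3.2 percentage points higher from compound 1 to compound 3 (within the scatter) lies within the scatter, whereas a number 15.7 percentage points higher from compound 1 to compound 2 (beyond the scatter) and a number 12.5 percentage points lower from compound 2 to compound 3 (beyond the scatter) lie beyond it. Compound 4 `CCCCNC(=O)CC1CCc2cc(OC)c(OC)cc21` differs from compound 3 by methyl in place of hydrogen on a saturated chain carbon, three bonds along the chain from an amide-type nitrogen. Among the compounds with values here, the only measured step of the same kind, chain growth on the amide nitrogen by one carbon, is a number 3.2 percentage points higher from compound 1 to compound 3 (within the scatter), which stayed within the scatter; no step beyond the scatter is therefore expected in this assay for compound 4. Compound 4 is estimated at 21% (range 9% to 34%), an expected step of a number 2.2 percentage points higher from compound 3 to compound 4 (within the scatter).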

Compound 4, a percentage reported as inhibition, in the whole organism at one dose (the size of the read-out at that dose, not a potency): 31.3%
For compound 4 the middle estimate is 10.3 percentage points below the measured one; low and high end bracket the measured number.
By their numbers in this assay, from the lowest: compounds 1 and 3 (each within the scatter of the next); then compounds 2 and 4 (each within the scatter of the next).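

In this assay, methyl in place of hydrogen three bonds along the chain from an amide-type nitrogen gives a number 12.5 percentage points higher from compound 3 to compound 4 (beyond the scatter) and so, unlike the same change two bonds along, moves the number beyond the scatter. Ethyl in place of hydrogen at the two-bond carbon gives a number 15.7 percentage points higher from compound 1 to compound 4 (beyond the scatter) across the whole extension, while butylamino in place of diethylamino gives no change at the digits printed from compound 2 to compound 4 (within the scatter) and leaves the two compounds indistinguishable here. No evidence bears on why the step appears at this position. Still open, on these data alone, is whether a longer chain such as pentyl or hexyl on the amide nitrogen holds, raises or lowers the number.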